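Bromo for hydroxy on the benzoyl ring of compound 2

This account rests on a few compounds, and the source may have more. Where it says the series, first, only, none or still open, it means among the compounds named here.

Among the compounds with values here, compound 2 `O=C(NN=C(c1ccccn1)c1ccccn1)c1ccc(O)cc1` gives 7530 nM in an ADME assay on cells (Homo sapiens) for antiproliferative activity, read by MTT assay (on this read-out lower numbers stand for stronger inhibition and higher numbers for weaker inhibition), the highest of the two numbers so far; the nearest is compound 1 `O=C(NN=C(c1ccccn1)c1ccccn1)c1cccs1` at 950 nM, and the step of a 7.9-fold higher number from compound 1 to compound 2 (0.90 log units; beyond the scatter) came with the change from thiophen-2-yl to 4-hydroxyphenyl on the carbonyl carbon. Compound 3 `O=C(NN=C(c1ccccn1)c1ccccn1)c1ccc(Br)cc1` keeps that core and carries bromo in place of hydroxy on an aromatic carbon. Within the data shown here, no measured step covers a hydroxy-to-bromo exchange; the single step measured concerns a different position, so it bears only loosely. A modest move back toward compound 1 is expected, a 2.5-fold lower number from compound 2 to compound 3 (0.40 log units; beyond the scatter), with wide uncertainty. Compound 3 is estimated at 3000 nM, within 800 nM to 12000 nM.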

Compound 3, half-maximal inhibitory concentration: 300 nM
Compound 3: the middle estimate sits 10-fold (1.00 log units) above what was measured; measured number outside the range, below it.
By their numbers in this assay, from the lowest: compound 3; then compound 1; then compound 2.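

In this assay, exchanging only hydroxy for bromo on the aromatic carbon gives a 25-fold lower number from compound 2 to compound 3 (1.40 log units; beyond the scatter), so this single substituent strongly affects the read-out. The 4-bromophenyl group also gives a 3.2-fold lower number from compound 1 to compound 3 (0.50 log units; beyond the scatter) against thiophen-2-yl, so the high number of compound 2 does not hold for every six-membered aromatic ring on the carbonyl carbon. No evidence at hand accounts for either step.

Still open, from the compounds shown here alone, is whether the gain is specific to bromo or would also appear with chloro, methoxy or an amine on the same aromatic carbon. A carboxylic acid there would test the same position further.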